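This account rests on a few compounds, and the source may have more. Where it says the series, first, only, none or still open, it means among the compounds named here.

Compound 1 `CC1=CC[C@H]2[C@H](CC[C@]2(C)O)C(C)(C)[C@@H]1CC[C@H]1[C@]2(C)CC[C@H](OC(=O)c3ccc(Cl)cc3)C(C)(C)O[C@H]2CC[C@@]1(C)O`: 24100 nM
Compound 2 `CC(=O)O[C@H]1CC[C@]2(C)[C@H](CC[C@@](C)(O)[C@H]2CC[C@@H]2C(C)=CC[C@@H]3C(C)=CC[C@@H]3C2(C)C)OC1(C)C`: 43500 nM
Compound 3 `CC1=CC[C@H]2[C@H](CC[C@]2(C)O)C(C)(C)[C@@H]1CC[C@H]1[C@]2(C)CC/C(=N/O)C(C)(C)O[C@H]2CC[C@@]1(C)O`: 46800 nM

In a functional assay on MCF7 cells (Homo sapiens) for antiproliferative activity, read by MTT assay, with a stated time of 72 h (on this read-out lower numbers stand for stronger inhibition and higher numbers for weaker inhibition), compound 1 shows the lowest of the three numbers, yet compound 2 and compound 3 both lie within the usual scatter of it, so the three cannot be told apart on these data. Compound 4 `CC1=CC[C@H]2[C@H](CC[C@]2(C)O)C(C)(C)[C@@H]1CC[C@H]1[C@]2(C)CC[C@H](OC(=O)c3ccccc3[N+](=O)[O-])C(C)(C)O[C@H]2CC[C@@]1(C)O` is built on the same core as compound 1 and differs from it by 2-nitrophenyl in place of 4-chlorophenyl on a carbonyl carbon. For the measured compounds named here, no measured pair shows a change of this kind, so the expectation rests on compound 1 alone. The step expected across this change is a 1.0-fold higher number from compound 1 to compound 4 (0.02 log units; within the scatter), not beyond the scatter in either direction. Compound 4 is therefore estimated to give about 25000 nM, within a range from 10000 nM to 60000 nM.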

Compound 4, half-maximal inhibitory concentration: 5200 nM
For compound 4 the middle estimate is 4.8-fold (0.68 log units) above the measured one; the whole stated range lies above it.
By their numbers in this assay, from the lowest: compound 4; then compounds 1, 2 and 3 (each within the scatter of the next).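

For the compounds shown here, until now the three compounds could not be told apart, but this position gives the first change beyond the scatter: in this assay, 2-nitrophenyl in place of 4-chlorophenyl on a carbonyl carbon gives a 4.6-fold lower number from compound 1 to compound 4 (0.67 log units; beyond the scatter). The group on this carbonyl carbon can therefore shift the read-out, although the step is modest. Nothing measured here accounts for the step. This single pair changes both the substituent and its ring position, so either could be responsible. Going by these compounds, whether 4-nitrophenyl, 2-chlorophenyl or plain phenyl would give a similar number remains open.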